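The source may hold more compounds than are shown below. What is called first, only, known or untested is meant among the compounds shown, and "the series" means these compounds.

Measured compounds:
- compound 1 `CCN(CC)c1nc(C)nc(N(CC)c2c(Br)cc(OC)cc2OC)n1`, which in an assay on isolated protein for binding affinity to corticotropin-releasing factor receptor 1 (Homo sapiens) (on this read-out lower numbers stand for stronger inhibition and higher numbers for weaker inhibition), gives 10 nM
- compound 2 `CCN(CC)c1cc(C)nc(N(CC)c2c(Cl)cc(OC)cc2Cl)n1`, which in this assay gives 15 nM

Compound 2 carries the higher of the two numbers, but its gap to compound 1 lies within the scatter, so the two compounds cannot be ranked on these data. Compound 3 `CCN(CC)c1cc(C)nc(N(CC)c2c(Cl)cc(OC)cc2OC)n1` has not yet been tested. It differs from compound 2 in one place: methoxy in place of chloro on an aromatic carbon. The new group sits on an aromatic carbon of a six-membered aromatic ring of carbon only, ortho to a large group, meta to a chloro group and meta to a methoxy group. Among the compounds with values here, no directly comparable step has been measured, so the expectation rests on the two values alone, which are close to each other. The step from compound 2 to compound 3 is expected to be small, a 1.4-fold lower number from compound 2 to compound 3 (0.13 log units; within the scatter), with no clear direction beyond the scatter. Compound 3 is therefore estimated at 11 nM, between 3.5 nM and 35 nM.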

Compound 3, inhibition constant: 10 nM
Compound 3: the middle estimate sits 1.1-fold (0.04 log units) above what was measured; the range from low to high includes it.
By their numbers in this assay, from the lowest: compounds 1, 3 and 2 (each within the scatter of the next).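

In this assay, within the data shown here, the step of a 1.5-fold lower number from compound 2 to compound 3 (0.18 log units; within the scatter) is the first direct reading of this position, and it lies within the scatter, so compound 2 and compound 3 cannot be ranked. On an aromatic carbon ortho to a large group, methoxy in place of chloro adds a hydrogen-bond acceptor and one more heavy atom, yet the read-out does not separate the two compounds. Nothing measured here speaks to the reason for this result.

What the compounds shown leave open is how this position would respond to a hydroxyl, an ethoxy or a longer chain, or a dimethylamino group. On these data alone, with a single step available, it also remains open whether the same exchange would read alike with other groups elsewhere on the shared core.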